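This account rests on a few compounds, and the source may have more. Where it says the series, first, only, none or still open, it means among the compounds named here.

Working notes on the series in a functional assay on UACC-62 cells (Homo sapiens) for cytotoxicity, read by sulforhodamine B assay; a higher number here means that more compound is tolerated, a lower number that less compound is tolerated.

The shared core is that of compound 1, `CC1=CC[C@@H]([C@@](C)(O)CCCC(C)(C)NC(=S)N/N=C\c2ccccc2)CC1`, which in this assay gives 48400 nM. Two variations on the aromatic ring are measured. Compound 2, `CC1=CC[C@@H]([C@@](C)(O)CCCC(C)(C)NC(=S)N/N=C\c2ccc(C)cc2)CC1`, gives 52300 nM in this assay; compound 3, `CC1=CC[C@@H]([C@@](C)(O)CCCC(C)(C)NC(=S)N/N=C\c2ccc(O)cc2)CC1`, gives 55600 nM. All three numbers lie within the scatter of one another: the change from compound 1 to compound 2 is a 1.1-fold higher number from compound 1 to compound 2 (0.03 log units; within the scatter), that from compound 1 to compound 3 is a 1.1-fold higher number from compound 1 to compound 3 (0.06 log units; within the scatter), and that from compound 2 to compound 3 is a 1.1-fold higher number from compound 2 to compound 3 (0.03 log units; within the scatter). Compound 1 thus stands together with compounds 2 and 3, none of the three separated from another beyond the scatter.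

Compound 4, `CC1=CC[C@@H]([C@@](C)(O)CCCC(C)(C)NC(=S)N/N=C\c2cccc([N+](=O)[O-])c2)CC1`, is not yet measured in this assay. It differs from compound 1 in one place: nitro in place of hydrogen on an aromatic carbon. The measured steps that bear on this are the two substitutions on the aromatic ring of compound 1, each of which stayed within the scatter. No step beyond the scatter is therefore expected for compound 4 in this assay, in either direction; the expected step is a 1.0-fold higher number from compound 1 to compound 4 (0.01 log units; within the scatter). The number for compound 4 is estimated at 50000 nM, with a range from 25000 nM to 100000 nM.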

Compound 4, concentration lethal to 50% of the cells: 49300 nM
Beside the measured number, compound 4's estimate is 1.0-fold (0.01 log units) above it; the range from low to high includes it.
By their numbers in this assay, from the lowest: compounds 1, 4, 2 and 3 (each within the scatter of the next).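

In this assay, among these compounds, nitro is the first group to sit meta to a large group, whereas compounds 2 and 3 carry methyl and hydroxy elsewhere on the ring, and the step on adding it stays within the scatter (a 1.0-fold higher number from compound 1 to compound 4 (0.01 log units; within the scatter)). The two swaps of whole aryl groups also stay within the scatter (a 1.1-fold lower number from compound 3 to compound 4 (0.05 log units; within the scatter); a 1.1-fold lower number from compound 2 to compound 4 (0.03 log units; within the scatter)), so phenyl, 4-methylphenyl, 4-hydroxyphenyl and 3-nitrophenyl cannot be told apart in this assay, and the tolerance of change on the ring now extends to a group of three heavy atoms that brings two hydrogen-bond acceptors and no donor. Nothing at hand accounts for this flat response to substitution on the ring.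

The compounds shown leave open whether an amine or a carboxylic acid on the ring would also stay within the scatter of compound 1. Among the compounds shown here, they also leave open whether the number moves at all when the change lies away from the ring, for example a longer chain in place of the one carrying the hydroxy group in the shared core.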